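A few compounds are considered here, and "the series" means these few. Any claim that something is new, unique, unknown or untested is made for them only; others in the source may bear on it.

Going by the values given here, compound 1 `CCCNc1ccc(NC(=O)c2cc(Cl)ccc2O)c(Cl)c1` stands at the top of the two numbers so far in an ADME assay on A549 cells (Homo sapiens) for cytotoxicity, read by resazurin assay, with a stated time of 48 h; on this read-out lower numbers stand for higher toxicity in this test and higher numbers for lower toxicity in this test: compound 1 gives 22500 nM, whereas compound 2 `CCCN(CCC)c1ccc(NC(=O)c2cc(Cl)ccc2O)c(Cl)c1` gives 10700 nM, and the step of a 2.1-fold lower number from compound 1 to compound 2 (0.32 log units; beyond the scatter) lies beyond the scatter. Compound 3 `O=C(Nc1ccc(NCc2cccc(C(F)(F)F)c2)cc1Cl)c1cc(Cl)ccc1O` is built on the same shared core but differs from compound 1 by 3-(trifluoromethyl)phenyl in place of ethyl on a saturated chain carbon bound to a nitrogen on an aromatic ring. Among the compounds with values here, only the single step from compound 1 to compound 2 is available to guide an expectation, and it concerns a propyl in place of hydrogen on a nitrogen on an aromatic ring, not the saturated chain carbon altered here; that step was modest. Because a 2.1-fold lower number from compound 1 to compound 2 (0.32 log units; beyond the scatter) moved the number downward when the side chain grew, a modest downward step is expected for compound 3 as well, with wide uncertainty. Compound 3 is therefore estimated at 12000 nM, between 4000 nM and 35000 nM, corresponding to an expected step of a 1.9-fold lower number from compound 1 to compound 3 (0.27 log units; within the scatter).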

Compound 3, half-maximal cytotoxic concentration: 13300 nM
Compound 3: the middle estimate sits 1.1-fold (0.04 log units) below what was measured; the measured number falls inside the stated range.
By their numbers in this assay, from the lowest: compounds 2, 3 and 1 (each within the scatter of the next, the first and the last beyond it).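

In this assay, the saturated chain carbon bound to the nitrogen on the aromatic ring accepts a much larger substituent without a change that can be distinguished from the scatter, as 3-(trifluoromethyl)phenyl with its 10 heavy atoms in place of ethyl with its 2 gives a 1.7-fold lower number from compound 1 to compound 3 (0.23 log units; within the scatter). Going by these compounds alone, the earlier pair spoke only to propyl in place of hydrogen on the nitrogen, whereas this step is the first to probe the chain carbon and to place an aromatic ring there. No measurement on hand accounts for this result.

The compounds shown leave open how an unsubstituted phenyl, a longer chain or a carboxylic acid at this place would read. They also do not separate the contribution of the trifluoromethyl group from that of the ring carrying it.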